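This account rests on a few compounds, and the source may have more. Where it says the series, first, only, none or still open, it means among the compounds named here.

Compound 1 `CC(C)Oc1ccc(Nc2nc(=O)n(CCO)c(=O)n2Cc2ccc(Cl)cc2)cc1Cl`: 0.001
Compound 2 `CC(C)Oc1ccc(/N=c2\[nH]c(=O)n(C[C@@H](O)CO)c(=O)n2Cc2ccc(Cl)cc2)cc1Cl`: 0.001
Compound 3 `C[C@@H](Cn1c(=O)[nH]/c(=N\c2ccc(Oc3ccccn3)cc2)n(Cc2ccc(Cl)cc2)c1=O)C(=O)O`: 0.01

In an ADME assay on the whole organism (plasma, Rattus norvegicus) for protein binding, using cassette dosing, at a dose of 1 mg/kg (on this read-out higher numbers stand for a larger free fraction and lower numbers for a smaller free fraction), compound 3 gives 0.01, the highest of the three numbers. Compound 1 gives 0.001 and compound 2 gives 0.001; both gaps to compound 3 lie beyond the usual scatter of this assay. Compound 4 `C[C@@H](Cn1c(=O)[nH]/c(=N\c2ccc(OC3CCC3)cc2)n(Cc2ccc(Cl)cc2)c1=O)C(=O)O` has not yet been measured. It differs from compound 3 in a single place: cyclobutyl in place of pyridin-2-yl on an oxygen on an aromatic ring. Among the compounds with values here, no measured pair carries this same change, so there is no measured step to lean on. The expected step is a 1.7-fold lower number from compound 3 to compound 4 (0.22 log units; within the scatter), a modest move downward that may still fall within the scatter. Compound 4 is therefore estimated at 0.006, with a range from 0.002 to 0.02.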

Compound 4, unbound fraction: 0.015
Beside the measured number, compound 4's estimate is 2.5-fold (0.40 log units) below it; low and high end bracket the measured number.
By their numbers in this assay, from the lowest: compounds 1 and 2 (each within the scatter of the next); then compounds 3 and 4 (each within the scatter of the next).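

Measured in this assay the swap of pyridin-2-yl for cyclobutyl on an oxygen on an aromatic ring gives a 1.5-fold higher number from compound 3 to compound 4 (0.18 log units; within the scatter) and so the two compounds cannot be told apart. At this position, then, in this one pair, an aromatic ring carrying a nitrogen and a smaller all-carbon ring read alike. Nothing measured here explains this result.

From the compounds shown here alone, whether a methyl group or a piperidine on that oxygen would read the same stays open. Compounds 1 and 2 differ from compound 3 in more than one place, so what separates them also stays unresolved.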